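The compounds below may be only part of what the source reports. "The series", "measured", "known", "first", "only" and "open" are said of these compounds alone.

Two close relatives open this account. Compound 1 `Cn1ccc2c(Oc3ccc(NC(=O)c4cc5cccnc5n(-c5ccc(F)cc5)c4=O)cc3F)ccnc21` carries a fluoro group on its outer benzene ring, and in a functional assay on A549 cells (Homo sapiens) for antiproliferative activity, read by MTT assay, with a stated time of 72 h (a lower number here means a stronger inhibitor, a higher number a weaker inhibitor), compound 1 gives 280 nM. Compound 2 `Cn1ccc2c(Oc3ccc(NC(=O)c4cc5cccnc5n(-c5ccc(Cl)cc5)c4=O)cc3F)ccnc21` has chloro in place of fluoro on an aromatic carbon, and in this assay compound 2 gives 350 nM. On these two numbers compound 2 stands next to compound 1, since the step of a 1.3-fold higher number from compound 1 to compound 2 (0.10 log units; within the scatter) lies within the scatter and the two compounds cannot be told apart. Compound 3 `Cn1ccc2c(Oc3ccc(NC(=O)c4cc5cccnc5n(-c5ccc(Br)cc5)c4=O)cc3F)ccnc21` takes one more step along the same halogen line: bromo in place of chloro on an aromatic carbon. Among the measured compounds shown here, the only measured step that bears on this change is the earlier exchange of one halogen for another, and it moved almost nothing. The step from compound 2 to compound 3 is therefore expected to be a 1.1-fold higher number from compound 2 to compound 3 (0.06 log units; within the scatter), not beyond the scatter. In this assay compound 3 is estimated to give 400 nM, with a likely range from 200 nM to 800 nM.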

Compound 3, half-maximal inhibitory concentration: 390 nM
The estimate for compound 3 lay 1.0-fold (0.01 log units) above the measured number; the range from low to high includes it.
By their numbers in this assay, from the lowest: compounds 1, 2 and 3 (each within the scatter of the next).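

In this assay, the exchange of chloro for bromo gives a 1.1-fold higher number from compound 2 to compound 3 (0.05 log units; within the scatter), so this second halogen swap at the same place also cannot be told from the scatter. Compound 3 also allows the first comparison across the whole line from fluoro to bromo, and even that longer jump reads a 1.4-fold higher number from compound 1 to compound 3 (0.14 log units; within the scatter), which leaves all three compounds level for this ring position, para to a large group. Nothing at hand says why these numbers sit so close together.

The compounds shown carry only halogens at this place, so the effect of an amine, a carboxylic acid or a methoxy group there remains open. Whether such a group would move the number beyond the scatter cannot be told from these three compounds.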